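The compounds below may be only part of what the source reports. "The series", "measured", "known", "first", "only" and "open" are said of these compounds alone.

Three compounds give the frame for this step. In a functional assay on the whole organism (strain Sprague-Dawley) for inhibition, with Rattus norvegicus as the target, with a stated time of 10 min (a lower number here means that less compound is needed, a higher number that more compound is needed for the effect), compound 1 `CCOc1ccccc1-c1ncc(C(=O)O)c(=O)[nH]1` gives 0.5 mg/kg. Compound 2 `CCOc1ccc(S(=O)(=O)N(C)C)cc1-c1ncc(C(=O)O)c(=O)[nH]1` reaches only the limit of this assay at > 50 mg/kg. Compound 3 `CCOC(=O)c1cnc(-c2ccccc2OCC)[nH]c1=O` gives 2 mg/kg in this assay, which puts it at the highest of the two numbers that are not a limit, with compound 1 as its nearest neighbour, separated by a 4.0-fold higher number from compound 1 to compound 3 (0.60 log units; beyond the scatter). The other measured step, an at least 100-fold higher number from compound 1 to compound 2 (2.00 log units; beyond the scatter), is a large one and ends at the limit of > 50 mg/kg in this assay, at which 1 of the 3 values shown sits.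

Compound 4 `CCOC(=O)c1cnc(-c2ccccc2SCC)[nH]c1=O` has not yet been tested. It differs from compound 3 by ethylsulfanyl in place of ethoxy on an aromatic carbon. Neither measured step touches this part of the molecule: one changed the ester side of the core, the other added dimethylsulfamoyl on the aromatic ring, so neither bears directly on the swap of ethoxy for ethylsulfanyl. Among the measured compounds shown here, with no step to lean on, the expectation is that the number for compound 4 stays close to that of compound 3, with a step of a 1.5-fold higher number from compound 3 to compound 4 (0.18 log units; within the scatter) that is estimated to fall within the scatter or only slightly beyond it. Compound 4 is therefore expected to give about 3 mg/kg in this assay, within a range from 1 mg/kg to 10 mg/kg.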

Compound 4, dose for 50% inhibition: > 5 mg/kg
Compound 4 was reported as a limit; the forecaster's own chance of this, stated with the estimate: 10%; at least 1.6-fold (0.22 log units) between middle value and limit.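

In this assay, compound 4 is reported only as a limit, not as a number: the limit of > 5 mg/kg in this assay, at which 1 of the 4 values shown sits.

Even so, the change is not silent, since the step is an at least 2.5-fold higher number from compound 3 to compound 4 (0.39 log units; beyond the scatter). Among the compounds shown here, it is the first measured step at this position on the aromatic carbon, ortho to a large group, and it shows that the position responds to a swap in which ethoxy and ethylsulfanyl match in their counts of heavy atoms, hydrogen-bond donors and hydrogen-bond acceptors, with sulfur taking the place of oxygen. The earlier steps shown here, on the ester side of the core and on the added dimethylsulfamoyl, said nothing about this position, and the new step shows that ethylsulfanyl here goes with more compound being needed than ethoxy does.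

On these data alone, how large the step really is remains open, as the limit gives only its lower bound, and it is also open whether the same swap would carry over to the free carboxylic acid of compound 1. How a longer chain such as propoxy, or an amine, would behave at this position is equally unsettled by the compounds shown.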